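A few compounds are considered here, and "the series" means these few. Any claim that something is new, unique, unknown or untested is made for them only; others in the source may bear on it.

Compound 1 `Cc1nn(C)c(C)c1-c1ccc(-c2nnc(N(C)Cc3ccc4nccn4c3)o2)cc1` serves as the reference point for the pair at hand. In an assay on COS-7 cells for inhibition of tyrosine-protein kinase receptor UFO (Homo sapiens), read by ELISA, with a stated time of 1 h (a higher number here means a weaker inhibitor, a lower number a stronger inhibitor), compound 1 gives 3160 nM. Compound 2 `Cc1nn(C)c(C)c1-c1ccc(-c2nnc(N(C)Cc3ccc4nccn4c3)o2)c(F)c1` carries a fluoro in place of hydrogen on an aromatic carbon, and in this assay compound 2 gives 3160 nM. Among the measured compounds shown here, the step of no change at the digits printed from compound 1 to compound 2 (within the scatter) is flat, so compound 2 stands level with compound 1 within the scatter; it is the only measured compound near it.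

Compound 3 `Cc1nn(C)c(C)c1-c1ccc(-c2nnc(N(C)Cc3ccc4nccn4c3)o2)c(Cl)c1` has not yet been measured. It differs from compound 2 by chloro in place of fluoro on an aromatic carbon, a chloro in place of fluoro on an aromatic carbon, ortho to a large group and meta to the 1,3,5-trimethyl-1H-pyrazol-4-yl group. For the measured compounds named here, the one measured step touching this position is no change at the digits printed from compound 1 to compound 2 (within the scatter), which brought no change when the fluoro entered. Going by the values given here, no measured compound carries a chloro at this position, so the direction of the halogen exchange is not anchored by data. On that basis the expected step is a 1.3-fold lower number from compound 2 to compound 3 (0.10 log units; within the scatter) in this assay, nothing beyond the scatter. Compound 3 is thus estimated at 2500 nM, within a range from 800 nM to 8000 nM.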

Compound 3, half-maximal inhibitory concentration: 794 nM
The estimate for compound 3 lay 3.1-fold (0.50 log units) above the measured number; measured number below the stated range.
By their numbers in this assay, from the lowest: compound 3; then compounds 1 and 2 (each within the scatter of the next).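

In this assay this position proves responsive to a substituent after all, but the response depends on which halogen sits there: exchanging fluoro for chloro brings a 4.0-fold lower number from compound 2 to compound 3 (0.60 log units; beyond the scatter) and so separates two groups that each replace a single hydrogen. Set against the parent hydrogen, chloro gives a 4.0-fold lower number from compound 1 to compound 3 (0.60 log units; beyond the scatter) whereas fluoro gave no change at the digits printed from compound 1 to compound 2 (within the scatter), so the flat first step at this carbon, ortho to a large group and meta to the 1,3,5-trimethyl-1H-pyrazol-4-yl group, did not speak for halogens in general. Nothing available here accounts for this difference between chloro and fluoro.

With only hydrogen, fluoro and chloro shown at this carbon, it remains open whether the lower number continues with bromo or iodo, or whether it also appears with a methyl, methoxy or trifluoromethyl group in the same place. Among the compounds shown here, the compounds also leave open whether chloro at another carbon of this ring would give a similar step, and whether the step would hold on a core other than the one shared by these compounds.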